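The compounds below may be only part of what the source reports. "The series", "measured", "known", "first", "only" and "open" are said of these compounds alone.

Measured compounds:
compound 1 `N#Cc1cccc(S(=O)(=O)Oc2ccc(-c3cncn3C3CCN(C(=O)c4ccc(Cl)c(C(F)(F)F)c4)CC3)cc2)c1` — 4.28 nM
compound 2 `CNC(=O)c1cccc(S(=O)(=O)Oc2ccc(-c3cncn3C3CCN(C(=O)c4ccc(Cl)c(C(F)(F)F)c4)CC3)cc2)c1` — 1.76 nM
compound 3 `O=C(c1ccc(Cl)c(C(F)(F)F)c1)N1CCC(n2cncc2-c2ccc(OS(=O)(=O)c3cccc4cnccc34)cc2)CC1` — 22 nM

These three share one core and differ only in the group attached to the sulfonyl sulfur. In an assay on THP-1 cells for antagonist activity at P2X purinoceptor 7 (Homo sapiens), read by ELISA, with a stated time of 30 min (on this read-out lower numbers stand for stronger inhibition and higher numbers for weaker inhibition), compound 2 gives 1.76 nM, compound 1 gives 4.28 nM, and compound 3 gives 22 nM, the highest of the three numbers. The steps to it are a 5.1-fold higher number from compound 1 to compound 3 (0.71 log units; beyond the scatter) and a 13-fold higher number from compound 2 to compound 3 (1.10 log units; beyond the scatter), both beyond the scatter. Between the two others the step is a 2.4-fold lower number from compound 1 to compound 2 (0.39 log units; beyond the scatter).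

Compound 4 `COc1ccc(C(=O)N2CCC(n3cncc3-c3ccc(OS(=O)(=O)c4cccc5cnccc45)cc3)CC2)cc1` keeps the isoquinolin-5-yl group of compound 3 on the sulfonyl sulfur and changes a different part of the molecule: 4-methoxyphenyl in place of 4-chloro-3-(trifluoromethyl)phenyl on a carbonyl carbon. Within the data shown here, none of the measured steps touches this carbonyl carbon; all three concern the sulfonyl sulfur, so they offer no direct precedent for this change. The expectation for compound 4 therefore rests on the structural change alone and carries wide uncertainty. A higher number than for compound 3 is expected, namely a step of a 6.8-fold higher number from compound 3 to compound 4 (0.83 log units; beyond the scatter). In this assay compound 4 is estimated at about 150 nM, within a range from 35 nM to 650 nM.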

Compound 4, half-maximal inhibitory concentration: 64 nM
Compound 4: middle estimate off by 2.3-fold (0.37 log units), on the high side; measured number inside the range.
By their numbers in this assay, from the lowest: compound 2; then compound 1; then compound 3; then compound 4.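

In this assay, among these compounds, the carbonyl carbon now has a step of its own: 4-methoxyphenyl in place of 4-chloro-3-(trifluoromethyl)phenyl gives a 2.9-fold higher number from compound 3 to compound 4 (0.46 log units; beyond the scatter) and shows that the group on this carbon matters, a point the earlier steps on the sulfonyl sulfur could not address. This step is smaller than a 13-fold higher number from compound 2 to compound 3 (1.10 log units; beyond the scatter) at the sulfonyl sulfur, so in these compounds a full exchange of the aromatic group on the carbonyl carbon moves the number less than the largest change seen at the sulfur. The exchange takes the group from 11 heavy atoms to 8 and brings in 1 hydrogen-bond acceptor, but no measurement shown here explains the higher number.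

Going by these compounds, the chlorine, the trifluoromethyl and the methoxy change together, so the share of each in the step stays unknown, and a plain phenyl group or a phenyl carrying only chlorine on this carbonyl carbon would help to separate them. Among the compounds shown here, the change is also seen only with isoquinolin-5-yl on the sulfonyl sulfur, so whether it gives a step of the same size with 3-cyanophenyl or 3-(methylcarbamoyl)phenyl there remains open.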